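From propyl to butyl on compound 1

The compounds below may be only part of what the source reports. "The series", "measured", "known", "first", "only" and "open" are said of these compounds alone.

compound 1 `CCCOC(=O)c1cc(N2C(=O)C3=C(CCCC3)C2=O)c(F)cc1Cl`: 33.1 nM
compound 2 `CCCOC(=O)c1cc(N2C(=O)C3=C(CCCC3)C2=O)ccc1Cl`: 1120 nM
compound 3 `CC(C)OC(=O)c1cc(N2C(=O)C3=C(CCCC3)C2=O)ccc1Cl`: 1230 nM

All three compounds were tested in a functional assay on the whole organism for inhibition, with Scenedesmus acutus as the target; a lower number here means a stronger inhibitor, a higher number a weaker inhibitor. Compound 1 has the lowest number of the three at 33.1 nM, and the values of compound 2 and compound 3 both lie far higher. Compound 4 `CCCCOC(=O)c1cc(N2C(=O)C3=C(CCCC3)C2=O)c(F)cc1Cl` has not yet been measured. Its structural change from compound 1 is methyl in place of hydrogen on a saturated chain carbon, three bonds along the chain from an oxygen next to a carbonyl group, which, cut further out, reads propyl to butyl.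

For the measured compounds named here, two measured steps bear on this change, neither directly. The large one, a 34-fold higher number from compound 1 to compound 2 (1.53 log units; beyond the scatter), is hydrogen in place of fluoro on an aromatic carbon, so it does not touch the chain. The closer one, a 1.1-fold higher number from compound 2 to compound 3 (0.04 log units; within the scatter), is isopropyl in place of propyl on an oxygen next to a carbonyl group, and it stays within the scatter. That step also concerns this chain, although compound 2 and compound 3 both lack the fluoro. Going by the values given here, no measured step lengthens the chain, so the evidence is thin. In this assay, no step beyond the scatter is therefore expected, and no clear direction. The expected result is a 1.2-fold higher number from compound 1 to compound 4 (0.08 log units; within the scatter). Compound 4 is estimated at 40 nM, with an expected range of 15 nM to 110 nM.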

Compound 4, half-maximal inhibitory concentration: 126 nM
Estimate against measurement, compound 4: 3.2-fold (0.50 log units) below; the measured number lies above the stated range.
By their numbers in this assay, from the lowest: compound 1; then compound 4; then compounds 2 and 3 (each within the scatter of the next).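

In this assay, propyl to butyl comes with a 3.8-fold higher number from compound 1 to compound 4 (0.58 log units; beyond the scatter), so a single added methyl, three bonds along the chain from an oxygen next to a carbonyl group, is enough to move the number beyond the scatter. For the compounds shown here, the only earlier step on this chain, a 1.1-fold higher number from compound 2 to compound 3 (0.04 log units; within the scatter), stayed within the scatter, but it replaced propyl with the branched isopropyl and was read on compounds that lack the fluoro, so its flat result did not carry over to lengthening the chain on the fluoro compound. The compounds offer no measurement that would account for the size of this step.

The compounds shown leave open whether a longer chain such as pentyl would raise the number further, or whether a shorter ethyl chain on the fluoro compound would lower it below that of compound 1. They also leave open whether the lengthening would have the same effect with hydrogen in place of fluoro, given the much larger a 34-fold higher number from compound 1 to compound 2 (1.53 log units; beyond the scatter) on that aromatic carbon.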